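Shortening the Chain on an Inactive Compound

The compounds below may be only part of what the source reports. "The series", "measured", "known", "first", "only" and "open" are said of these compounds alone.

In a functional assay on PC-3 cells (Homo sapiens) for antiproliferative activity, read by sulforhodamine B assay, with a stated time of 48 h (a higher number here means a weaker inhibitor of growth, a lower number a stronger inhibitor of growth), compound 1 (`CC(C)CCc1c(OCCCCCCC(=O)NO)ccc2c1OC(=O)CC2`) gives > 30000 nM and this is a limit, not a number. On a different core, compound 2 (`CC(C)CCc1c(OCCCCCCCC(=O)NO)ccc2ccc(=O)oc12`) gives 1730 nM and compound 3 (`CC(C)CCc1c(OCCCCC(=O)NO)ccc2ccc(=O)oc12`) gives 1940 nM in this assay as well. Compound 4 (`CC(C)CCc1c(OCCCCCC(=O)NO)ccc2c1OC(=O)CC2`) changes compound 1 by hydroxycarbamoyl in place of (hydroxycarbamoyl)methyl on a saturated chain carbon, five bonds along the chain from an oxygen on an aromatic ring so hydroxycarbamoyl stands in place of (hydroxycarbamoyl)methyl on a saturated chain carbon, five bonds along the chain from an oxygen on an aromatic ring. For the measured compounds named here, the only guide is a 1.1-fold higher number from compound 2 to compound 3 (0.05 log units; within the scatter) where a larger shortening of the chain stayed within the scatter, though on that other core. The expected move is therefore a number no higher from compound 1 to compound 4 (the limit leaves the size open) and thus no step beyond the scatter. For compound 4 the estimated value is 30000 nM with an expected range from 12000 nM to 60000 nM in this estimate.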

Compound 4, concentration for 50% growth inhibition: > 30000 nM
Compound 4: no number, only a limit; the forecaster's own chance of this, stated with the estimate: 75%; the middle value sits exactly at the limit.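

Compound 1 and compound 4 each give only a limit, not a number, in this assay, so no step can be read between them: the limit of > 30000 nM in this assay, at which 2 of the 4 values shown sit.

The compounds shown leave open whether any chain length on this core gives a readable number.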